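A few compounds are considered here, and "the series" means these few. Any claim that something is new, unique, unknown or untested is made for them only; others in the source may bear on it.

Three compounds have so far been measured in a functional assay on HT-29 cells (Homo sapiens) for cytotoxicity, read by MTT assay, with a stated time of 72 h; on this read-out lower numbers stand for stronger inhibition of growth and higher numbers for weaker inhibition of growth:

compound 1, `CC(C)COC(=O)Nc1ccc([Se][Se]c2ccc(NC(=O)OCC(C)C)cc2)cc1`: 48600 nM
compound 2, `CCCCOC(=O)Nc1ccc([Se]C#N)cc1`: 31300 nM
compound 3, `Cc1ccc(OC(=O)Nc2ccc([Se][Se]c3ccc(NC(=O)Oc4ccc(C)cc4)cc3)cc2)cc1`: 39400 nM

Compound 2 gives the lowest of the three numbers in this assay, yet its gaps to compound 3 and to compound 1 both fall within the scatter, so the three cannot be told apart on these data. Compound 4, `C=CCOC(=O)Nc1ccc([Se]C#N)cc1`, has not yet been measured in this assay. It differs from compound 2 by vinyl in place of propyl on a saturated chain carbon bound to an oxygen next to a carbonyl group. Among the measured compounds shown here, no pair of measured compounds shows this change, and nothing in the three values points to a direction for it. The change is small, and the expectation is no step beyond the scatter in this assay. Compound 4 is therefore estimated at 30000 nM in this assay, with a range from 12000 nM to 75000 nM. The expected step is a 1.0-fold lower number from compound 2 to compound 4 (0.02 log units; within the scatter).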

Compound 4, concentration for total growth inhibition: 48600 nM
Estimate against measurement, compound 4: 1.6-fold (0.21 log units) below; the measured number falls inside the stated range.
By their numbers in this assay, from the lowest: compounds 2, 3, 1 and 4 (each within the scatter of the next).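

In this assay, among the compounds shown here, vinyl in place of propyl on a saturated chain carbon bound to an oxygen next to a carbonyl group gives the first step that can be read at this position (a 1.6-fold higher number from compound 2 to compound 4 (0.19 log units; within the scatter)), and it stays within the scatter. On this read-out, butoxy and allyloxy therefore cannot be told apart. No available evidence bears on this result. The compounds shown leave open whether a longer chain, a benzyl group or an amine at this place would give a step beyond the scatter.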